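The source may report more compounds than this note shows. Statements on the series, on what has been measured and on what is new or still open speak of the compounds shown alone.

Compound 1, with the structure `C#CCOc1ccc2c(=O)c(-c3cc(OC)c(OC)cc3OC)coc2c1`, is tested in a functional assay on A-375 cells (Homo sapiens) for antiproliferative activity, read by MTT assay, with a stated time of 24 h (on this read-out lower numbers stand for stronger inhibition and higher numbers for weaker inhibition), where compound 1 gives 3680 nM. Among the two plain numbers shown, compound 1 carries the highest one, and its nearest neighbour is compound 2, `COc1ccc2c(=O)c(-c3cc(OC)c(OC)cc3OC)coc2c1`, for which compound 2 gives 2640 nM; the change a 1.4-fold lower number from compound 1 to compound 2 (0.14 log units; within the scatter) is a small one, lying within the scatter. The third compound, compound 3 with the structure `COc1cccc(C(=O)Oc2ccc3c(=O)c(-c4cc(OC)c(OC)cc4OC)coc3c2)c1`, is reported only as a limit of the assay: compound 3 gives > 10000 nM, which is the limit noted as the limit of > 10000 nM in this assay, at which 1 of the 3 values shown sits. The step of an at least 2.7-fold higher number from compound 1 to compound 3 (0.43 log units; beyond the scatter) and the step of an at least 3.7-fold higher number from compound 2 to compound 3 (0.57 log units; beyond the scatter) both run toward higher numbers, beyond the scatter.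

Compound 4, `COc1cc(OC)c(-c2coc3cc(OCC(=O)c4cccc(C(F)(F)F)c4)ccc3c2=O)cc1OC`, is not yet measured. It differs from compound 1 in one place: (3-(trifluoromethyl)phenyl)carbonyl in place of ethynyl on a saturated chain carbon bound to an oxygen on an aromatic ring. Within the data shown here, the steps that bear on this are the two in which a carbonyl-bearing aromatic group entered in place of a small alkyl or propargyl group, since both led to weaker inhibition. A step toward a higher number in this assay is therefore expected, probably of at least modest size, and the estimated step of a 2.4-fold higher number from compound 1 to compound 4 (0.39 log units; beyond the scatter) reflects that. Compound 4 is expected to give about 9000 nM, within a range from 3000 nM to 25000 nM.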

Compound 4, half-maximal inhibitory concentration: > 10000 nM
Compound 4 ended at the assay's limit; the forecaster's own chance of this, stated with the estimate: 40%; middle value at least 1.1-fold (0.04 log units) away from the limit.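

In this assay compound 4 gives > 10000 nM, which is a limit of the assay and not a number, and it shares that limit with another compound: the limit of > 10000 nM in this assay, at which 2 of the 4 values shown sit. Both new steps are therefore minimum sizes, an at least 2.7-fold higher number from compound 1 to compound 4 (0.43 log units; beyond the scatter) and an at least 3.7-fold higher number from compound 2 to compound 4 (0.57 log units; beyond the scatter), so the true loss of inhibition could be larger. Compound 3 carries its aromatic carbonyl group on an oxygen on an aromatic ring, whereas compound 4 carries one on a saturated chain carbon bound to an oxygen on an aromatic ring, which shows that weak inhibition also appears with this second attachment; none of the four compounds goes against this link between an aromatic carbonyl group and the limit.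

Compound 4 brings in a carbonyl, an aromatic ring and a trifluoromethyl group in a single change, so the compounds shown cannot tell which of these parts goes with the weaker result, and a plain benzyl group or a chain ending in an amine or a carboxylic acid would help to separate them. Compound 3 and compound 4 also cannot be ranked against each other, since both sit at the limit.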